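This account rests on a few compounds, and the source may have more. Where it says the series, first, only, none or still open, it means among the compounds named here.

Measured compounds:
Compound 1, `CC(C)Oc1ccc(CNC(=O)c2ccc(C(C)(C)C)cc2)cc1`, in an assay on HeLa cells with Bile acid receptor (Homo sapiens) as the target, read by a luciferase reporter, with a stated time of 24 h (a higher number here means that more compound is needed for the effect, a lower number that less compound is needed), compound 1 gives 170 nM.
Compound 2, `O=C(O)c1ccc(CNC(=O)c2cccc(-c3ccccc3)c2)cc1`, in this assay compound 2 gives 670 nM.

Of these two, compound 1 has the lower number; the value of compound 2 lies a good way above it, beyond the usual scatter, so compound 1 needs less compound for the effect than compound 2. Compound 3, `CN(C)C(=O)c1ccc(CNC(=O)c2ccc(C(C)(C)C)cc2)cc1`, has not been measured. It differs from compound 1 in one place: dimethylcarbamoyl in place of isopropoxy on an aromatic carbon. Going by the values given here, no pair of measured compounds shows this exchange, so its effect is not known from the data. Among the compounds with values here, the amide carries a second acceptor-like position but no donor, and the only hint comes from compound 2, where a different polar group at the same end goes with a higher number. Compound 3 is therefore expected to need somewhat more compound than compound 1, with the estimated step of a 2.4-fold higher number from compound 1 to compound 3 (0.37 log units; beyond the scatter) uncertain in size. For compound 3 the estimate in this assay is 400 nM, with a range from 120 nM to 1500 nM.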

Compound 3, half-maximal effective concentration: 170 nM
The estimate for compound 3 lay 2.4-fold (0.37 log units) above the measured number; the range from low to high includes it.
By their numbers in this assay, from the lowest: compounds 1 and 3 (each within the scatter of the next); then compound 2.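

In this assay, the aromatic carbon para to a large group accepts dimethylcarbamoyl in place of isopropoxy, with no change at the digits printed from compound 1 to compound 3 (within the scatter) despite the entering group bringing a nitrogen and a double bond outside aromatic rings. Going by these compounds alone, this is the first single-place comparison, as compound 1 and compound 2 differ in more than one place, and it shows that the ether and the amide are interchangeable here for this read-out. No measurement at hand speaks to the reason for this result.

As far as these compounds go, what remains open is whether this position accepts other groups as readily, such as a primary amine, a carboxylic acid on the core of compound 1, or a longer alkoxy chain. From the compounds shown here alone, whether the same exchange gives the same result on a different core also remains open.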